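Urea series: working notes toward compound 4

A few compounds are considered here, and "the series" means these few. Any claim that something is new, unique, unknown or untested is made for them only; others in the source may bear on it.

Measured compounds in a functional assay on HepG2 cells (Homo sapiens) for inhibition, read by MTT assay, with a stated time of 120 h; on this read-out lower numbers stand for stronger inhibition and higher numbers for weaker inhibition:
compound 1 `CC(NC(=O)C#Cc1ccc(NC(=O)Nc2cc(C(F)(F)F)ccc2Cl)cc1)c1ccccc1`: 19000 nM
compound 2 `O=C(/C=C/c1ccc(NC(=O)Nc2ccc(Cl)c(C(F)(F)F)c2)cc1)NC1CCC1`: 7510 nM
compound 3 `CC(NC(=O)/C=C/c1ccc(NC(=O)Nc2ccc(Cl)c(C(F)(F)F)c2)cc1)c1ccccc1`: 12200 nM

Compound 2 holds the lowest of the three numbers in this assay. Its nearest neighbour is compound 3, and that gap, a 1.6-fold higher number from compound 2 to compound 3 (0.21 log units; within the scatter), stays within the scatter, so the two cannot be ordered. Compound 1 stands furthest from compound 2, and that gap is beyond the scatter; compound 1 and compound 2 differ in more than one place, so only their two values can be set side by side.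

Compound 4 `CNC(=O)c1cccc(-c2ccc(NC(=O)Nc3ccc(Cl)c(C(F)(F)F)c3)cc2)c1` is not yet measured. Relative to compound 2 the change is 3-(methylcarbamoyl)phenyl in place of 2-(cyclobutylcarbamoyl)ethenyl on an aromatic carbon. Going by the values given here, the one measured step, from compound 2 to compound 3, alters the amide substituent and not the link between the two aryl parts, and it is within the scatter. Among the compounds with values here, no measured step touches the link itself, so there is nothing here to point in either direction. The expectation for compound 4 is therefore no step beyond the scatter, a 1.1-fold higher number from compound 2 to compound 4 (0.03 log units; within the scatter). Compound 4 is estimated at 8000 nM, with a range from 2500 nM to 25000 nM, the width reflecting that the change is of a kind not covered by any measured step.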

Compound 4, half-maximal inhibitory concentration: 37100 nM
Compound 4: middle estimate off by 4.6-fold (0.67 log units), on the low side, and the stated range ends below it.
By their numbers in this assay, from the lowest: compounds 2, 3, 1 and 4 (each within the scatter of the next, the first and the last beyond it).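

In this assay, 3-(methylcarbamoyl)phenyl in place of 2-(cyclobutylcarbamoyl)ethenyl, on an aromatic carbon para to a large group, gives a 4.9-fold higher number from compound 2 to compound 4 (0.69 log units; beyond the scatter), so this position shows a step beyond the scatter, whereas the change on the amide nitrogen gave only a 1.6-fold higher number from compound 2 to compound 3 (0.21 log units; within the scatter). The leaving and entering groups carry the same count of hydrogen-bond donors and acceptors and no net charge, so those counts do not separate them; they differ in the four-membered non-aromatic ring leaving, the six-membered aromatic ring entering, and the double bonds outside aromatic rings. No measurement at hand bears on the origin of this step.

The change replaces the link and the amide substituent in a single move, so the compounds shown cannot assign the step to either part: cyclobutyl on the amide nitrogen of the entering phenyl group, or methyl on that of the ethenyl group, would separate the two. Also open, from the compounds shown here alone, is how this position responds to a group without the amide, such as a carboxylic acid or a primary amine.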